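The source may report more compounds than this note shows. Statements on the series, on what has been measured and on what is new or still open speak of the compounds shown alone.

Within the data shown here, in a functional assay on the whole organism for positive allosteric modulation, with Mus musculus as the target (a higher number here means that more compound is needed for the effect, a lower number that less compound is needed), compound 1 `CCC(=O)N(c1ccc(Cl)cc1)C1CCCCC1N(C)C` gives 35 mg/kg as the only exact number so far. Compound 2 `CCC(=O)N(c1ccc(OC)cc1)C1CCCCC1N(C)C` gives > 50 mg/kg as a limit of the assay, not a number. Among the measured compounds shown here, the one measured step, methoxy in place of chloro on an aromatic carbon, is an at least 1.4-fold higher number from compound 1 to compound 2 (0.15 log units; that floor lies within the scatter) and fixes only a floor. Compound 3 `CCC(=O)N(c1cccc(C)c1)C1CCCCC1N(C)C` differs from compound 1 by 3-methylphenyl in place of 4-chlorophenyl on an amide-type nitrogen in one swap, 3-methylphenyl in place of 4-chlorophenyl on an amide-type nitrogen. For the measured compounds named here, with the step to compound 2 as the only guide, no shift beyond the scatter is expected. The expected change in this assay is a 1.1-fold higher number from compound 1 to compound 3 (0.06 log units; within the scatter) and nothing larger. Compound 3 is estimated at 40 mg/kg with an expected range of 20 mg/kg to 80 mg/kg overall.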

Compound 3, dose for half-maximal effect: > 50 mg/kg
Compound 3: only a limit was reported; the forecaster's own chance of this, stated with the estimate: 35%; middle value at least 1.2-fold (0.09 log units) from the limit.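

In this assay the change to 3-methylphenyl in place of 4-chlorophenyl on the amide-type nitrogen is an at least 1.4-fold higher number from compound 1 to compound 3 (0.15 log units; that floor lies within the scatter), so it fixes only a floor. For compound 3, > 50 mg/kg is a limit of the assay and not a number. Two different replacements of the 4-chlorophenyl group now end at a limit, and compound 2 and compound 3 cannot be ordered because both sit at the same limit: the limit of > 50 mg/kg in this assay, at which 2 of the 3 values shown sit.

As far as these compounds go, whether either replacement truly raises the number over compound 1 stays open, as the floor lies within the scatter. Also open, from the compounds shown here alone, is what a 4-fluorophenyl or 4-aminophenyl group would give at this place.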